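Methoxy on the aromatic ring: working notes on four compounds

A few compounds are considered here, and "the series" means these few. Any claim that something is new, unique, unknown or untested is made for them only; others in the source may bear on it.

Measured in a functional assay on RD cells (Homo sapiens) for inhibition, read by MTT assay, with a stated time of 72 h; on this read-out higher numbers stand for weaker inhibition and lower numbers for stronger inhibition:
compound 1 `CN1C(=O)N(C)C2C1NC(=S)N2/N=C/C=C/c1ccccc1`: 46000 nM
compound 2 `COc1ccc(/C=C/C=N/N2C(=S)NC3C2N(C)C(=O)N3C)cc1`: > 100000 nM, a limit of the assay rather than a number
compound 3 `CN1C(=O)N(c2ccccc2)C2NC(=S)N(/N=C/C=C/c3ccccc3)C21`: 1690 nM

Compound 3 differs from compound 1 by phenyl in place of methyl on an amide-type nitrogen in a ring, and the step is a 27-fold lower number from compound 1 to compound 3 (1.43 log units; beyond the scatter), so compound 3 stands lowest of the two numbers.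

Compound 2 differs from compound 1 by methoxy in place of hydrogen on an aromatic carbon; the step is an at least 2.1-fold higher number from compound 1 to compound 2 (0.33 log units; beyond the scatter), and its size rests on (the limit of > 100000 nM in this assay, at which 1 of the 3 values shown sits).

Compound 4 `COc1ccccc1/C=C/C=N/N1C(=S)NC2C1N(C)C(=O)N2c1ccccc1` is not yet measured. It differs from compound 3 by methoxy in place of hydrogen on an aromatic carbon. This is the same kind of change as that from compound 1 to compound 2, but not the same: in compound 2 the methoxy sits para to a large group, in compound 4 ortho to a large group.

The expected step is a 2.7-fold higher number from compound 3 to compound 4 (0.43 log units; beyond the scatter), placed beside an at least 2.1-fold higher number from compound 1 to compound 2 (0.33 log units; beyond the scatter) on the view that the methoxy weakened compound 2 against compound 1 and may do likewise here, with wider uncertainty since the place differs. Compound 4 is therefore estimated at 4500 nM, within 1200 nM to 18000 nM.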

Compound 4, half-maximal inhibitory concentration: 20 nM
Estimate against measurement, compound 4: 230-fold (2.35 log units) above; measured number outside the range, below it.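

In this assay, methoxy in place of hydrogen on an aromatic carbon gives an 85-fold lower number from compound 3 to compound 4 (1.93 log units; beyond the scatter), so the step on the core of compound 3 runs against the step on the core of compound 1, and the two do not agree: the same change on two cores in this assay, an at least 2.1-fold higher number (0.33 log units; beyond the scatter) from compound 1 to compound 2 and an 85-fold lower number (1.93 log units; beyond the scatter) from compound 3 to compound 4, at least 180-fold (2.26 log units) apart, beyond the scatter of two such steps. This shows that neither the direction nor the size of the step carried over from one core to the other, but it does not show that the core alone sets the outcome, since the methoxy of compound 4 is ortho to a large group and the methoxy of compound 2 stands at a different place, so core and place change together. Compound 2 stands at a limit of the assay rather than a number: the limit of > 100000 nM in this assay, at which 1 of the 4 values shown sits.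

Left open is whether the step from phenyl to 2-methoxyphenyl would hold on the core of compound 1, and whether a methoxy at another place on the ring would give a similar step on the core of compound 3. Also open, going by these compounds, is what an amine, a carboxylic acid or an ethoxy group would do at the place the methoxy holds in compound 4.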